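Removing the Hydroxy Group from the Lactone Ring

This account rests on a few compounds, and the source may have more. Where it says the series, first, only, none or still open, it means among the compounds named here.

Compound 3 `C=C1CC[C@H](C)[C@@](C)(CCC2=CC(O)OC2=O)C/C=C\C=C/1C(=O)O`: 4100 nM
Compound 2 `C[C@H]1CC[C@@]2(C)C(C(=O)O)=CCC[C@H]2[C@]1(C)CCC1=CCOC1=O`: 7300 nM
Compound 1 `C=C1CC[C@H](C)[C@@](C)(CCC2=CC(OCC)OC2=O)C/C=C\C=C/1C(=O)O`: 12000 nM

In an assay on isolated protein (strain Wistar) for inhibition of Voltage-gated L-type calcium channel (Rattus norvegicus) (a lower number here means that less compound is needed, a higher number that more compound is needed for the effect), compound 3 has the lowest of the three numbers shown, though compound 2 sits within the usual scatter of it and only compound 1 lies beyond it. For the measured compounds named here, the single measured step, a 2.9-fold lower number from compound 1 to compound 3 (0.47 log units; beyond the scatter), shows a modest gain when the ethyl on that oxygen is replaced by hydrogen. Compound 4 `C=C1CC[C@H](C)[C@@](C)(CCC2=CCOC2=O)C/C=C\C=C/1C(=O)O` goes further: hydrogen in place of hydroxy on a saturated ring carbon. Compound 2, which also carries no hydroxy on its ring, gives 7300 nM, close to compound 3. Going by the values given here, no measured step covers this change directly, so only a small shift is expected, a 1.5-fold higher number from compound 3 to compound 4 (0.17 log units; within the scatter), probably within the scatter. Compound 4 is therefore estimated at 6000 nM, ranging from 2500 nM to 14000 nM.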

Compound 4, half-maximal effective concentration: 14000 nM
For compound 4 the middle estimate is 2.3-fold (0.37 log units) below the measured one; measured number inside the range.
By their numbers in this assay, from the lowest: compounds 3, 2, 1 and 4 (each within the scatter of the next, the first and the last beyond it).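

Removing the hydroxy group from this saturated ring carbon has a measurable cost, with a 3.4-fold higher number from compound 3 to compound 4 (0.53 log units; beyond the scatter) when hydrogen takes its place. Hydrogen and ethoxy at this carbon cannot be told apart, with a 1.2-fold higher number from compound 1 to compound 4 (0.07 log units; within the scatter) between them, so of the three groups only hydroxy stands out. No available evidence explains why hydroxy differs from the other two. From the compounds shown here alone, whether the lower number depends on the hydroxy group itself remains open. A methoxy group, an amine or a fluorine on this carbon would test that.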